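The source may hold more compounds than are shown below. What is called first, only, known or untested is meant among the compounds shown, and "the series" means these compounds.

Compound 1 `O=C(Nc1cccc(-n2cc(-c3ccncc3)c(-c3ccc(Cl)c(O)c3)n2)c1)Nc1cccc(C(F)(F)F)c1` and compound 2 `COc1cc(-c2nn(-c3cccc(NC(=O)c4cccc(C(F)(F)F)c4)c3)cc2-c2ccncc2)ccc1Cl` have been measured in a functional assay on U-251 cells (Homo sapiens) for inhibition, read by sulforhodamine B assay, with a stated time of 48 h; on this read-out higher numbers stand for weaker inhibition of growth and lower numbers for stronger inhibition of growth. In this assay compound 1 gives 1590 nM, and compound 2 gives 1620 nM; compound 2 holds the highest of the two numbers, but its gap to compound 1 lies within the scatter, so the two values show no difference. Among the measured compounds shown here, these two compounds differ in more than one place, and no single step between them can be read. Compound 3 `COc1cc(-c2nn(-c3cccc(NC(=O)Nc4ccc(Cl)c(Cl)c4)c3)cc2-c2ccncc2)ccc1Cl` has not yet been measured in this assay. It differs from compound 2 by (3,4-dichlorophenyl)amino in place of 3-(trifluoromethyl)phenyl on a carbonyl carbon. Compound 1 already carries a carbamoyl linkage of this kind together with the 3-(trifluoromethyl)phenyl group and gives a value within the scatter of compound 2, so no step beyond the scatter is expected here. For compound 3 a value of 1500 nM is expected, with a range from 600 nM to 4000 nM. The expected step is thus a 1.1-fold lower number from compound 2 to compound 3 (0.03 log units; within the scatter), nothing beyond the scatter.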

Compound 3, concentration for 50% growth inhibition: 820 nM
Compound 3: middle estimate off by 1.8-fold (0.26 log units), on the high side; the measured number falls inside the stated range.
By their numbers in this assay, from the lowest: compounds 3, 1 and 2 (each within the scatter of the next).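

In this assay, the exchange of 3-(trifluoromethyl)phenyl for (3,4-dichlorophenyl)amino on the carbonyl carbon gives a 2.0-fold lower number from compound 2 to compound 3 (0.30 log units; within the scatter), the first single-place step readable in the series, and it does not go beyond the scatter. This position therefore tolerates the change from (3-(trifluoromethyl)phenyl)carbonyl to (3,4-dichlorophenyl)carbamoyl without a clear difference in growth inhibition, although the swap alters both the link to the ring and the ring's substituents at once. No available data bear on a cause for this result.

The contributions of the added amino link and the two chlorines cannot be separated with these compounds. Also open, on these data alone, is how this position responds to a non-aromatic group, such as a cyclohexyl ring or a morpholine, in place of the substituted phenyl ring.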